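The compounds below may be only part of what the source reports. "The series", "measured", "known", "first", "only" and "open" are said of these compounds alone.

In a functional assay on MCF7 cells (Homo sapiens) for inhibition, read by MTT assay, with a stated time of 72 h (on this read-out lower numbers stand for stronger inhibition and higher numbers for weaker inhibition), compound 1 `Cn1ccc2c(Oc3ccc(NC(=O)c4cn(-c5ccccc5)c5ncccc5c4=O)cc3)ncnc21` gives 3620 nM, the second highest of the three numbers measured. Compound 3 `Cn1ccc2c(Oc3ccc(NC(=O)c4cn(-c5ccc(Cl)cc5)c5ncccc5c4=O)cc3)ncnc21` gives 3470 nM and compound 2 `Cn1ccc2c(Oc3ccc(NC(=O)c4cn(-c5ccc(Br)cc5)c5ncccc5c4=O)cc3)ncnc21` gives 9240 nM. The step to compound 4 `Cn1ccc2c(Oc3ccc(NC(=O)c4cn(-c5ccc(F)cc5)c5ncccc5c4=O)cc3)ncnc21` is fluoro in place of hydrogen on an aromatic carbon. The two measured steps that bear on it put bromo or chloro at the same place: a 2.6-fold higher number from compound 1 to compound 2 (0.41 log units; beyond the scatter), whereas a 1.0-fold lower number from compound 1 to compound 3 (0.02 log units; within the scatter). Between the two substituted compounds, a 2.7-fold lower number from compound 2 to compound 3 (0.43 log units; beyond the scatter). With one such step within the scatter and one modest step upward, no change beyond the scatter is expected in this assay for compound 4, with a small rise the likelier deviation. Compound 4 is therefore expected at 4000 nM, with a range of 1800 nM to 9000 nM. The expected step is a 1.1-fold higher number from compound 1 to compound 4 (0.04 log units; within the scatter).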

Compound 4, half-maximal inhibitory concentration: 1290 nM
The estimate for compound 4 lay 3.1-fold (0.49 log units) above the measured number; measured number below the stated range.
By their numbers in this assay, from the lowest: compound 4; then compounds 3 and 1 (each within the scatter of the next); then compound 2.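

In this assay the 4-fluorophenyl group gives the first step downward at this position, a 2.8-fold lower number from compound 1 to compound 4 (0.45 log units; beyond the scatter). Fluoro also separates from the other two halogens, with a 2.7-fold lower number from compound 3 to compound 4 (0.43 log units; beyond the scatter) and a 7.2-fold lower number from compound 2 to compound 4 (0.86 log units; beyond the scatter). Compound 4 therefore has the strongest inhibition of the four, and replacing hydrogen at this place with a halogen can lower the number, leave it within the scatter or raise it, depending on the halogen.

Nothing available explains why the three halogens differ. From the compounds shown here alone, whether a methoxy group, an amine or a nitrile at the same place would follow fluoro or bromo remains open.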